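Sulfur for oxygen, and an expected half-life for compound 3

The source may report more compounds than this note shows. Statements on the series, on what has been measured and on what is new or still open speak of the compounds shown alone.

Compound 1 `COc1ccccc1OC[C@@H]1CCc2cc([C@H]3CC[C@](N)(CO)C3)ccc2C1` and compound 2 `COc1ccccc1SC[C@@H]1CCc2cc([C@H]3CC[C@](N)(CO)C3)ccc2C1` share one core. Going by the values given here, in an ADME assay on the whole organism (Rattus norvegicus, strain Lewis) for metabolic stability, at a dose of 2 mg/kg by the oral route (a higher number here means that the compound lasts longer, a lower number that the compound disappears faster), compound 1 gives 14 h, the lower of the two numbers known so far; compound 2 gives 24 h, and the step of a 1.7-fold higher number from compound 1 to compound 2 (0.23 log units; within the scatter) lies within the scatter. Compound 3 `COc1cccc(SC[C@@H]2CCc3cc([C@H]4CC[C@](N)(CO)C4)ccc3C2)c1` differs from compound 1 by (3-methoxyphenyl)sulfanyl in place of 2-methoxyphenoxy on a saturated chain carbon bound to a saturated ring carbon. Among the compounds with values here, the only measured step that bears on this change is a 1.7-fold higher number from compound 1 to compound 2 (0.23 log units; within the scatter), which also brings a sulfanyl group in place of a phenoxy group, so no step beyond the scatter is expected, a 1.3-fold higher number from compound 1 to compound 3 (0.11 log units; within the scatter). Compound 3 is therefore estimated at 18 h, between 9 h and 36 h.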

Compound 3, half-life: 21 h
Beside the measured number, compound 3's estimate is 1.2-fold (0.07 log units) below it, within the range that was stated.
By their numbers in this assay, from the lowest: compounds 1, 3 and 2 (each within the scatter of the next).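

In this assay the step of a 1.1-fold lower number from compound 2 to compound 3 (0.06 log units; within the scatter) shows that 3-methoxyphenyl in place of 2-methoxyphenyl on a sulfur changes the half-life by no more than the scatter. The step of a 1.5-fold higher number from compound 1 to compound 3 (0.18 log units; within the scatter) shows the same for the (3-methoxyphenyl)sulfanyl group replacing 2-methoxyphenoxy, so neither swap separates these compounds. No evidence is available to explain these numbers. Still open, from the compounds shown here alone, is whether a group other than methoxy on the ring, such as an amine or a carboxylic acid, or a longer chain in place of the sulfur, would give a step beyond the scatter.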